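A few compounds are considered here, and "the series" means these few. Any claim that something is new, unique, unknown or untested is made for them only; others in the source may bear on it.

Three compounds share one core and differ only in the side group attached to it. Within the data shown here, compound 1 `C#CCNC1CCc2c(OCc3cccc(C(F)(F)F)c3)cccc21` is the first; in an assay on isolated protein for inhibition of Amine oxidase [flavin-containing] B (Homo sapiens) (on this read-out higher numbers stand for weaker inhibition and lower numbers for stronger inhibition), compound 1 gives 6410 nM. Compound 2 `C#CCNC1CCc2c(SCc3cccc(F)c3)cccc21` gives 1480 nM in this assay. Compound 3 `C#CCNC1CCc2c(SCc3ccc(F)cc3F)cccc21` gives 2430 nM in this assay. Compound 2 holds the lowest of the three numbers: its gap to compound 3 lies within the usual scatter of repeated measurements, while its gap to compound 1 lies beyond it. Compound 4 `C#CCNC1CCc2c(SCc3cccc(Br)c3)cccc21`, not yet measured, differs from compound 2 by bromo in place of fluoro on an aromatic carbon. Among the measured compounds shown here, no measured pair shows this exact change, so the step expected in this assay is modest, a 1.2-fold lower number from compound 2 to compound 4 (0.09 log units; within the scatter), in no direction beyond the scatter. Compound 4 is expected to give 1200 nM, within a range from 400 nM to 3600 nM.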

Compound 4, half-maximal inhibitory concentration: > 100000 nM
Compound 4 ended at the assay's limit; the forecaster's own chance of this, stated with the estimate: 5%; middle value at least 83-fold (1.92 log units) away from the limit.
By their numbers in this assay, from the lowest: compounds 2 and 3 (each within the scatter of the next); then compound 1. At a limit, above all of these: compound 4.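

Bromo in place of fluoro on this aromatic carbon, a swap of one atom for one atom, gives an at least 67-fold higher number from compound 2 to compound 4 (1.82 log units; beyond the scatter) in this assay, so at this position the choice of halogen can matter greatly. The earlier compounds shown here carry only fluoro or trifluoromethyl on this ring, and their numbers gave no sign of such a loss. The result for compound 4 is a limit and not a number, so the true size of the step stays unknown: the limit of > 100000 nM in this assay, at which 1 of the 4 values shown sits.

On these data alone, whether chloro here would behave like fluoro or like bromo remains open. So does the effect of a methyl or a methoxy group at this position.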